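This account rests on a few compounds, and the source may have more. Where it says the series, first, only, none or still open, it means among the compounds named here.

Measured compounds:
compound 1, `COc1cc2c(Oc3ccc(NC(=O)c4nn(-c5ccccc5C(F)(F)F)c(=O)cc4C)cc3F)ccnc2cc1OCCCN1CCCC1`, giving 1010 nM in a functional assay on U-87MG ATCC cells (Homo sapiens) for inhibition, read by MTT assay, with a stated time of 72 h; on this read-out higher numbers stand for weaker inhibition and lower numbers for stronger inhibition
compound 2, `COc1cc2c(Oc3ccc(NC(=O)c4nn(-c5ccccc5C(F)(F)F)c(=O)cc4C)cc3F)ccnc2cc1OCCCN1CCCCC1`, giving 1150 nM
compound 3, `COc1cc2c(Oc3ccc(NC(=O)c4nn(-c5ccccc5C(F)(F)F)c(=O)cc4C)cc3F)ccnc2cc1OCCCN1CCN(C)CC1`, giving 1170 nM

These three share one core and differ only in the saturated ring at the end of the chain that hangs off an oxygen on the aromatic ring. On the numbers shown, compound 2 gives the second highest number of the three, but the gaps are small: a 1.1-fold higher number from compound 1 to compound 2 (0.06 log units; within the scatter) and a 1.0-fold higher number from compound 2 to compound 3 (0.01 log units; within the scatter) both lie within the scatter, so the three compounds cannot be told apart on these data.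

Compound 4, `COc1cc2c(Oc3ccc(NC(=O)c4nn(-c5cccc(F)c5)c(=O)cc4C)cc3F)ccnc2cc1OCCCN1CCCCC1`, changes a different part of the molecule: 3-fluorophenyl in place of 2-(trifluoromethyl)phenyl on an aromatic nitrogen. Among the measured compounds shown here, none of the measured steps touches this ring; each of them swapped only the amine at the end of the chain and gave no movement beyond the scatter. For the measured compounds named here, no measured step therefore bears directly on the change from compound 2 to compound 4, and the expectation rests on no comparison at all. Absent guidance, the expected step of a 1.3-fold higher number from compound 2 to compound 4 (0.12 log units; within the scatter) is set near no change, with a wide range. Compound 4 is thus estimated at 1500 nM, between 400 nM and 6000 nM.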

Compound 4, half-maximal inhibitory concentration: 1500 nM
Beside the measured number, compound 4's estimate shows no gap at the digits printed; the measured number falls inside the stated range.
By their numbers in this assay, from the lowest: compounds 1, 2, 3 and 4 (each within the scatter of the next).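

Among the compounds shown here, this is the first comparison at the ring on the aromatic nitrogen, as the earlier steps changed only the amine at the end of the chain. In this assay, putting 3-fluorophenyl in place of 2-(trifluoromethyl)phenyl gives a 1.3-fold higher number from compound 2 to compound 4 (0.12 log units; within the scatter), so these two compounds cannot be told apart. At least for this one pair, a group of 10 heavy atoms can give way to one of 7 with no movement beyond the scatter, but nothing measured here explains that result.

This swap alters both the substituent and the place it occupies on the phenyl ring, and the two contributions cannot be separated on these data. On these data alone, it also remains open how the number would respond to a plain phenyl ring, a pyridine ring or a small methyl group on that nitrogen.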